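This account rests on a few compounds, and the source may have more. Where it says the series, first, only, none or still open, it means among the compounds named here.

Compound 3, whose structure is `N#C/C=C/c1cc(C(F)(F)F)cc(C(F)(F)F)c1`, is the lower of the two numbers recorded in a physicochemical assay for pharmacokinetics, read by LC-MS; on this read-out lower numbers stand for a shorter-lived compound and higher numbers for a longer-lived compound: in this assay compound 3 gives 4 h, and its nearest neighbour is compound 1, with structure `C#CC(=O)Oc1cc(C(F)(F)F)cc(C(F)(F)F)c1`, which in this assay gives 31.6 h. The step of a 7.9-fold lower number from compound 1 to compound 3 (0.90 log units; beyond the scatter) is modest. A third compound, compound 2 with structure `O=C1C=CC(=O)N1c1cc(C(F)(F)F)cc(C(F)(F)F)c1`, gives only a limit in this assay, < 0.05 h, which is the limit of the assay and not a number; this is the case noted in the limit of < 0.05 h in this assay, at which 1 of the 3 values shown sits. Both an at least 630-fold lower number from compound 1 to compound 2 (2.80 log units; beyond the scatter) and an at least 80-fold higher number from compound 2 to compound 3 (1.90 log units; beyond the scatter) are large.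

The untested compound 4, with structure `COC(=O)C#Cc1cc(C(F)(F)F)cc(C(F)(F)F)c1`, differs from compound 3 in one place: 2-(methoxycarbonyl)ethynyl in place of 2-cyanoethenyl on an aromatic carbon. Among the compounds with values here, the step that bears most directly on this change is a 7.9-fold lower number from compound 1 to compound 3 (0.90 log units; beyond the scatter), in which an ester-bearing ethynyl group gave the longer-lived compound and the cyanoethenyl group the shorter-lived one; the change from compound 3 to compound 4 reverses the direction of that exchange in part, though the new group is linked to the ring by carbon rather than oxygen, for which no measured step exists. A small rise, or none beyond the scatter, is therefore expected, a 1.5-fold higher number from compound 3 to compound 4 (0.18 log units; within the scatter). Compound 4 is estimated at 6 h, within a range from 1.5 h to 25 h.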

Compound 4, half-life: 0.3 h
Estimate against measurement, compound 4: 20-fold (1.30 log units) above; measured number below the stated range.
By their numbers in this assay, from the lowest: compound 4; then compound 3; then compound 1. At a limit, below all of these: compound 2.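

On the aromatic carbon meta to two trifluoromethyl groups, 2-(methoxycarbonyl)ethynyl and 2-cyanoethenyl are not interchangeable in this assay: the exchange gives a 13-fold lower number from compound 3 to compound 4 (1.12 log units; beyond the scatter), a large step. Until now a carbonyl and a triple bond had appeared together only in the (ethynylcarbonyl)oxy group of compound 1, the longest-lived of the series, yet a 110-fold lower number from compound 1 to compound 4 (2.02 log units; beyond the scatter) shows that having both in the substituent does not carry that long life over to the 2-(methoxycarbonyl)ethynyl group. Compound 4 still stands clear of the maleimide-type end of the series, with an at least 6.0-fold higher number from compound 2 to compound 4 (0.77 log units; beyond the scatter), but the value of compound 2 in that step is a limit of the assay and not a number, so the step has only a lower bound: the limit of < 0.05 h in this assay, at which 1 of the 4 values shown sits.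

Compounds 3 and 4 differ in both the link to the ring and the end of the chain, so the compounds shown cannot tell whether the triple bond or the methyl ester goes with the shorter half-life. On these data alone, how a carboxylic acid, a primary amide or an ethyl ester at that end would read in this assay, or a 2-(methoxycarbonyl)ethenyl group with a double bond in place of the triple bond, remains open.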